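From 2-methylphenyl to 3-chlorophenyl on a shared core

The source may hold more compounds than are shown below. What is called first, only, known or untested is meant among the compounds shown, and "the series" means these compounds.

Of the compounds shown here, three with the same core have been tested so far in a functional assay on HL-60 cells (Homo sapiens) for antiproliferative activity, read by sulforhodamine B assay, with a stated time of 72 h (a higher number here means a weaker inhibitor, a lower number a stronger inhibitor), with these results. Compound 1 `S=C(NCc1ccccc1)N/N=C/c1ccc2ccccc2n1` gives 21900 nM there, compound 2 `S=C(N/N=C/c1ccc2ccccc2n1)Nc1cccc(Br)c1` gives 53800 nM there, and compound 3 `Cc1ccccc1NC(=S)N/N=C/c1ccc2ccccc2n1` gives 73200 nM in the same test. Compound 3 holds the top of these numbers only as a shared place: the data show a 1.4-fold higher number from compound 2 to compound 3 (0.13 log units; within the scatter) and so cannot separate the two. The benzyl compound stands apart, with a 2.5-fold higher number from compound 1 to compound 2 (0.39 log units; beyond the scatter) and a 3.3-fold higher number from compound 1 to compound 3 (0.52 log units; beyond the scatter) in the data.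

On these data alone, compound 4 `S=C(N/N=C/c1ccc2ccccc2n1)Nc1cccc(Cl)c1` is still untested. Its difference from compound 3 is 3-chlorophenyl in place of 2-methylphenyl on an amide-type nitrogen and in words it is 3-chlorophenyl in place of 2-methylphenyl on an amide-type nitrogen. The closest guide is compound 2, whose 3-bromophenyl group carries bromine where the new group carries chlorine. Exchanging that group for 2-methylphenyl gave a 1.4-fold higher number from compound 2 to compound 3 (0.13 log units; within the scatter) and no clear change, so no step beyond the scatter is expected in this assay for this swap. The estimate therefore means a 1.5-fold lower number from compound 3 to compound 4 (0.17 log units; within the scatter) as the expected outcome. For compound 4 the expected value is 50000 nM with a likely range from 25000 nM to 95000 nM in this estimate.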

Compound 4, half-maximal inhibitory concentration: 28800 nM
Estimate against measurement, compound 4: 1.7-fold (0.24 log units) above; measured number inside the range.
By their numbers in this assay, from the lowest: compounds 1, 4, 2 and 3 (each within the scatter of the next, the first and the last beyond it).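

In this assay, exchanging 2-methylphenyl for 3-chlorophenyl on the amide-type nitrogen gives a 2.5-fold lower number from compound 3 to compound 4 (0.41 log units; beyond the scatter), so the choice of aromatic group at this position can change the result, which the within-scatter step from compound 2 to compound 3 could not show. Chloro in place of bromo on the aromatic carbon gives a 1.9-fold lower number from compound 2 to compound 4 (0.27 log units; within the scatter), which is within the scatter, so the chlorine and bromine compounds cannot be told apart in this test. Benzyl no longer stands apart from every aromatic group placed directly on this nitrogen: 3-chlorophenyl in place of benzyl gives a 1.3-fold higher number from compound 1 to compound 4 (0.12 log units; within the scatter), also within the scatter, although compound 2 and compound 3 remain beyond the scatter from compound 1.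

No measurement offered here explains why the 2-methylphenyl and 3-chlorophenyl compounds differ. Still open, on these data alone, is whether an amine or a carboxylic acid on the phenyl ring, or a chain longer than benzyl on this nitrogen, would give a number clearly lower than that of compound 1.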